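Removing the Methyl from the Sulfonyl of Compound 2

The compounds below may be only part of what the source reports. "The series", "measured", "known", "first", "only" and "open" are said of these compounds alone.

Compound 1 `O=C(/C=C/c1ccccc1)c1ccc(N2CCN(c3ccccc3F)CC2)cc1` and compound 2 `Cc1ccc(S(=O)(=O)N2CCN(c3ccc(C(=O)/C=C/c4ccccc4)cc3)CC2)cc1` differ in one place. In a functional assay on the whole organism (strain Kunming) for inhibition, with Mus musculus as the target, with a stated time of 1 h, at a dose of 40 mg/kg by the oral route (on this read-out higher numbers stand for more inhibition at the one dose given (going by the name of the read-out) and lower numbers for less inhibition), compound 1 gives 0.57%, while compound 2 gives 30.8%, the higher of the two numbers, and the step of a number 30.2 percentage points higher from compound 1 to compound 2 (beyond the scatter) is large. Compound 3 `O=C(/C=C/c1ccccc1)c1ccc(N2CCN(S(=O)(=O)c3ccccc3)CC2)cc1` keeps the shared core of compound 2 and differs by hydrogen in place of methyl on an aromatic carbon. Within the data shown here, the only measured step concerns a different change and gives no direct guide; with no step of this kind among the measured compounds, a change within the scatter is expected, a number 3.8 percentage points lower from compound 2 to compound 3 (within the scatter). Compound 3 is therefore estimated at 27%, between 10% and 45%.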

Compound 3, a percentage reported as inhibition, in the whole organism at one dose (the size of the read-out at that dose, not a potency): 30%
Compound 3: the middle estimate sits 3 percentage points below what was measured; measured number inside the range.
By their numbers in this assay, from the lowest: compound 1; then compounds 3 and 2 (each within the scatter of the next).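

In this assay, taking the methyl off the (4-methylphenyl)sulfonyl group gives a number 0.8 percentage points lower from compound 2 to compound 3 (within the scatter) and so this aromatic carbon, para to a large group, does not separate hydrogen from methyl. The plain phenylsulfonyl group in place of 2-fluorophenyl gives a number 29.4 percentage points higher from compound 1 to compound 3 (beyond the scatter) and so the rise seen with compound 2 does not depend on that methyl. No evidence bearing on this result is available. On these data alone, whether a methoxy group, a chlorine atom or an amine on this carbon would move the number remains open. So does whether a carbonyl in place of the sulfonyl would keep it.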